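The source may report more compounds than this note shows. Statements on the series, on what has been measured and on what is new or still open speak of the compounds shown alone.

Measured compounds:

compound 1 `COc1cc(Cl)cc(-c2nn(-c3cccc(NC(=O)Nc4ccc(Cl)c(C(F)(F)F)c4)c3)cc2-c2ccncc2)c1` — 96%
compound 2 `COc1cc(Cl)cc(-c2nn(-c3cccc(NC(=O)Nc4cc(C(F)(F)F)cc(C(F)(F)F)c4)c3)cc2-c2ccncc2)c1` — 100%
compound 3 `COc1cc(Cl)cc(-c2nn(-c3cccc(NC(=O)Nc4ccc(Cl)c(Cl)c4)c3)cc2-c2ccncc2)c1` — 95%

The three compounds share one core and differ only in the aryl group carried on the amide-type nitrogen. In a functional assay on SK-MEL-5 cells (Homo sapiens) for inhibition, read by sulforhodamine B assay, with a stated time of 48 h, tested at 0.01 uM (a higher number here means a weaker effect of the compound at the concentration tested, a lower number a stronger effect), compound 1 gives 96%, compound 2 gives 100% and compound 3 gives 95%. Compound 3 holds the lowest of the three numbers, but its nearest neighbour, compound 1, is separated from it only by a number 1 percentage points lower from compound 1 to compound 3 (within the scatter), and compound 2 stands a few points higher still, all within the scatter, so the three are not distinguishable here.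

Compound 4 `COc1cc(Cl)cc(-c2nn(-c3cccc(NC(=O)Nc4cccc(C(F)(F)F)c4)c3)cc2-c2ccncc2)c1` has not yet been measured in this assay. It differs from compound 3 by 3-(trifluoromethyl)phenyl in place of 3,4-dichlorophenyl on an amide-type nitrogen. Among the measured compounds shown here, the only step that bears on this change is the one from compound 1 to compound 3, which was a number 1 percentage points lower from compound 1 to compound 3 (within the scatter); it swaps one substituent on the same aryl group and moves nothing beyond the scatter. Compound 4 is therefore expected to sit close to compound 3, with a step of about a number 2 percentage points higher from compound 3 to compound 4 (within the scatter). The estimate for compound 4 in this assay is 97%, expected to lie between 88% and 104%.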

Compound 4, a percentage reported as activity, at one concentration (the size of the read-out at that concentration, not a potency): 96%
Compound 4: middle estimate off by 1 percentage points, on the high side; low and high end bracket the measured number.
By their numbers in this assay, from the lowest: compounds 3, 1, 4 and 2 (each within the scatter of the next).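

In this assay, hydrogen in place of chloro on an aromatic carbon gives no change at the digits printed from compound 1 to compound 4 (within the scatter), and hydrogen in place of trifluoromethyl gives a number 4 percentage points lower from compound 2 to compound 4 (within the scatter), so removing either second substituent from the aryl group on this amide-type nitrogen moves the number by no more than the scatter. Replacing 3,4-dichlorophenyl with 3-(trifluoromethyl)phenyl gives a number 1 percentage points higher from compound 3 to compound 4 (within the scatter), which leaves the four aryl groups indistinguishable at this single concentration. Nothing in the data shown explains this result.

From the compounds shown here alone, it remains open whether an aryl group carrying an amine or a carboxylic acid would depart from these numbers. Going by these compounds, it also remains open whether the four compounds would separate at higher concentrations, where a stronger effect could be read.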